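The compounds below may be only part of what the source reports. "The series", "measured", "known", "first", "only" and "open" are said of these compounds alone.

Measured compounds:
- compound 1, `CCCCc1cc2ccccc2nc1-c1cc(-c2ccccc2)no1`: > 100000 nM
- compound 2, `CCCCCc1cc2ccccc2nc1-c1cc(-c2ccccc2)no1`: 92300 nM

Compound 1 gives no number in a functional assay on A549 cells (Homo sapiens) for inhibition, read by MTT assay, with a stated time of 24 h; on this read-out lower numbers stand for stronger inhibition and higher numbers for weaker inhibition; its entry is only a limit of the assay, (the limit of > 100000 nM in this assay, at which 1 of the 2 values shown sits). Compound 2 is therefore the only one of the two with a measured number, and in this assay compound 2 gives 92300 nM. Within the data shown here, the one step seen so far, an at least 1.0-fold lower number from compound 1 to compound 2 (0.03 log units; that floor lies within the scatter), is a lengthening of the saturated chain on the shared core, and its size sits within the ordinary scatter.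

Compound 3, `CCCCCc1cc2ccccc2nc1-c1cc(-c2ccc(C)cc2)no1`, is to be measured next. It differs from compound 2 by methyl in place of hydrogen on an aromatic carbon. Among the measured compounds shown here, no measured step concerns a change on this outer six-membered ring, so the chain step from compound 1 to compound 2 is the only guide, and it moved the number hardly at all. A step of similar, small size is expected here, a 1.2-fold lower number from compound 2 to compound 3 (0.06 log units; within the scatter), with no clear direction. Compound 3 is thus estimated at 80000 nM in this assay, within a range from 30000 nM to 200000 nM.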

Compound 3, half-maximal inhibitory concentration: > 100000 nM
Compound 3 ended at the assay's limit (the forecaster's own chance of this, stated with the estimate: 40%); at least 1.2-fold (0.09 log units) between middle value and limit.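

Among these compounds, the first change on the outer phenyl ring gives no sign of stronger inhibition. In this assay compound 3 gives > 100000 nM, and this entry is a limit of the assay, not a number. The step reads an at least 1.0-fold higher number from compound 2 to compound 3 (0.03 log units; that floor lies within the scatter), so phenyl to 4-methylphenyl, at a place para to a large group, adds no detectable inhibition, and the printed size of the step is only a floor, leaving its true size unknown. The compounds now show little room for comparison, with compound 2 alone keeping a measured number: the limit of > 100000 nM in this assay, at which 2 of the 3 values shown sit.

Still open, from the compounds shown here alone, is whether any other group on this ring would give a clear number in this assay, for example a methoxy group, a chlorine atom, an amine or a carboxylic acid in place of the methyl. Also open is whether a longer chain on the shared core would move the number beyond the usual scatter, as the single chain step shown cannot settle that question.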